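This account rests on a few compounds, and the source may have more. Where it says the series, first, only, none or still open, it means among the compounds named here.

Compound 1 `CCC1=C(O)c2c(oc(-c3ccc(Br)cc3)cc2=O)C(CC)(CC)C1=O` is measured in a functional assay on KB cells (Homo sapiens) for antiproliferative activity, read by sulforhodamine B assay, with a stated time of 3 days; a higher number here means that more compound is needed for the effect, a lower number that less compound is needed. Compound 1 gives > 48.1 uM, which is a limit of the assay rather than a number. Compound 2 `CCC1=C(O)c2c(oc(-c3cccc(C)c3)cc2=O)C(CC)(CC)C1=O` gives 49.7 uM. Compound 3 `CCC1=C(O)c2c(oc(-c3cccc(F)c3)cc2=O)C(CC)(CC)C1=O` gives > 56.2 uM, again a limit. Compound 1 thus stands only as a limit (the limit of > 48.1 uM in this assay, at which 1 of the 3 values shown sits), alongside a second limit in the set (the limit of > 56.2 uM in this assay, at which 1 of the 3 values shown sits). Compound 4 `CCC1=C(O)c2c(oc(-c3ccc(OC)c(F)c3)cc2=O)C(CC)(CC)C1=O` differs from compound 1 by 3-fluoro-4-methoxyphenyl in place of 4-bromophenyl on an aromatic carbon. Going by the values given here, the steps that bear on this are a step that the limit leaves unreadable from compound 1 to compound 2 and a step that the two limits leave unreadable from compound 1 to compound 3, both unreadable, while an at least 1.1-fold higher number from compound 2 to compound 3 (0.05 log units; that floor lies within the scatter) lies within the scatter. No step beyond the scatter is therefore expected for compound 4, and a limit is again likely. Compound 4 is expected at 50 uM, between 20 uM and 150 uM, a step that the limit leaves unreadable from compound 1 to compound 4.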

Compound 4, concentration for half-maximal effect: 26.7 uM
Estimate against measurement, compound 4: 1.9-fold (0.27 log units) above, within the range that was stated.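

Adding methoxy to the 3-fluorophenyl group gives an at least 2.1-fold lower number from compound 3 to compound 4 (0.32 log units; beyond the scatter), the first step beyond the scatter at this position. Neither of the other two steps is shown to lie beyond the scatter: an at least 1.8-fold lower number from compound 1 to compound 4 (0.25 log units; that floor lies within the scatter) and a 1.9-fold lower number from compound 2 to compound 4 (0.27 log units; within the scatter). The first of those two is only a floor because compound 1 stands as a limit: the limit of > 48.1 uM in this assay, at which 1 of the 4 values shown sits.

The compounds shown leave open how 4-methoxyphenyl without the fluoro would read. They also leave open what a phenyl carrying an amine or a carboxylic acid in place of the methoxy would give.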